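A Second Chloro Group Added to Compound 1

This account rests on a few compounds, and the source may have more. Where it says the series, first, only, none or still open, it means among the compounds named here.

Compound 1 `O=c1c(C(=S)Nc2ccccc2)coc2cc(Cl)ccc12` was tested in a functional assay on HEp-2 cells (Homo sapiens) for inhibition, read by sulforhodamine B assay, with a stated time of 48 h; a higher number here means a weaker inhibitor, a lower number a stronger inhibitor. In this assay compound 1 gives > 100000 nM, which is a limit of the assay and not a measured number. This is the weakest kind of result the assay reports, as the limit of > 100000 nM in this assay, at which 1 of the 2 values shown sits, shows. Compound 2 `O=c1c(C2N=C(c3ccccc3)SS2)coc2cc(Cl)c(Cl)cc12` gives 98000 nM in this assay, a very high concentration that also means only faint inhibition.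

Compound 3 `O=c1c(C(=S)Nc2ccccc2)coc2cc(Cl)c(Cl)cc12` has not yet been measured. It differs from compound 1 by chloro in place of hydrogen on an aromatic carbon. Among the compounds with values here, no measured pair shows what this change does on its own. Since compound 2 gives 98000 nM, a second result at the weak end of the scale, compound 3 is expected to stay weak as well. The expected step is a number no higher from compound 1 to compound 3 (the limit leaves the size open), nothing beyond the scatter. In this assay compound 3 is estimated at about 100000 nM, within a range of 40000 nM to 250000 nM.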

Compound 3, half-maximal inhibitory concentration: > 100000 nM
Compound 3 ended at the assay's limit (the forecaster's own chance of this, stated with the estimate: 60%); the middle value lies on the limit itself.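

No step from compound 1 to compound 3 can be read in this assay, because both compounds rest at a limit of the assay and not on a number: the limit of > 100000 nM in this assay, at which 2 of the 3 values shown sit.

The compounds shown leave open what chloro in place of hydrogen on an aromatic carbon does on its own to inhibition.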